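Methoxy for Nitro: Expecting a Partial Recovery

A few compounds are considered here, and "the series" means these few. Any claim that something is new, unique, unknown or untested is made for them only; others in the source may bear on it.

Of the compounds shown here, two built on the shared core have been measured in a functional assay on HCT-116 cells (Homo sapiens) for antiproliferative activity; a higher number here means a weaker inhibitor, a lower number a stronger inhibitor. Compound 1 (`COc1ccc(-c2snnc2-c2cc(OC)c(OC)c(OC)c2)cc1O`) gives 3 nM, while compound 2 (`COc1ccc(-c2snnc2-c2cc(OC)c(OC)c(OC)c2)cc1[N+](=O)[O-]`) gives 30.2 nM, the higher of the two numbers and so the weaker inhibitor of the pair. The next compound, compound 3 (`COc1ccc(-c2snnc2-c2cc(OC)c(OC)c(OC)c2)cc1OC`), carries methoxy in place of nitro on an aromatic carbon, ortho to a methoxy group and meta to a large group: methoxy in place of nitro on an aromatic carbon. Among the compounds with values here, only one measured step bears on this change. With nitro in place of hydroxy at that same carbon, the number moves a 10-fold higher number from compound 1 to compound 2 (1.00 log units; beyond the scatter), a modest step. Methoxy has not yet been measured there, so the data do not show whether it will track hydroxy or nitro. A position between the two measured compounds is therefore expected, somewhat closer to neither extreme. The expected change is a 2.5-fold lower number from compound 2 to compound 3 (0.40 log units; beyond the scatter), a smaller step than the measured one, toward a lower number. For compound 3 the estimate is 12 nM, with an expected range of 4 nM to 45 nM.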

Compound 3, half-maximal inhibitory concentration: 50.9 nM
Beside the measured number, compound 3's estimate is 4.2-fold (0.63 log units) below it; measured number above the stated range.
By their numbers in this assay, from the lowest: compound 1; then compounds 2 and 3 (each within the scatter of the next).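

In this assay, methoxy at this carbon does not track hydroxy: the step is a 17-fold higher number from compound 1 to compound 3 (1.23 log units; beyond the scatter), beyond the scatter, so methyl in place of hydrogen on that oxygen is enough to leave the low number of compound 1 behind. Nor does methoxy separate from nitro, since a 1.7-fold higher number from compound 2 to compound 3 (0.23 log units; within the scatter) lies within the scatter, and the two groups cannot be told apart in this assay. Across these three compounds, then, hydroxy alone stands apart at this carbon, with compound 2 and compound 3 each beyond the scatter from compound 1. Nothing available here explains this result.

Going by these compounds, whether an amine or a plain hydrogen at this carbon would stay close to compound 1 or fall in with compound 2 and compound 3 remains open, as does whether an ethoxy group would behave like methoxy. Also open, on these data alone, is whether the gap to hydroxy would persist if the methoxy group ortho to this carbon were changed as well.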